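Pyrimidine series: chlorothiophene replaces methoxyphenyl on the core

The compounds below may be only part of what the source reports. "The series", "measured", "known", "first", "only" and "open" are said of these compounds alone.

Measured so far:
compound 1 `CCOC(=O)c1cnc(C(F)(F)F)nc1NN1C(=O)C=C(C)C1=O` gives 1000 nM
compound 2 `CCOC(=O)c1cnc(-c2ccncc2)nc1NN1C(=O)C=C(C)C1=O` gives 6000 nM
compound 3 `CCOC(=O)c1cnc(-c2ccc(OC)cc2)nc1NN1C(=O)C=C(C)C1=O` gives 900 nM

In a functional assay on Jurkat cells for inhibition of nuclear factor NF-kappa-B complex (Homo sapiens) (on this read-out lower numbers stand for stronger inhibition and higher numbers for weaker inhibition), compound 3 holds the lowest of the three numbers; its nearest neighbour is compound 1, a 1.1-fold lower number from compound 1 to compound 3 (0.05 log units; within the scatter), which sits within the scatter, so the two cannot be ordered. The furthest is compound 2, a 6.7-fold lower number from compound 2 to compound 3 (0.82 log units; beyond the scatter), a step beyond the scatter.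

Compound 4 `CCOC(=O)c1cnc(-c2ccc(Cl)s2)nc1NN1C(=O)C=C(C)C1=O` is not yet measured. Its change from compound 3: 5-chlorothiophen-2-yl in place of 4-methoxyphenyl on an aromatic carbon.

Going by the values given here, no measured step exchanges one aromatic substituent for another of this kind except a 6.7-fold lower number from compound 2 to compound 3 (0.82 log units; beyond the scatter), which shows that swapping the aromatic group at this position can move the number by a modest amount; a 6.0-fold higher number from compound 1 to compound 2 (0.78 log units; beyond the scatter) shows the same in the other direction, whereas a 1.1-fold lower number from compound 1 to compound 3 (0.05 log units; within the scatter) shows two different groups giving equal numbers. Among the compounds with values here, an aromatic group that is not a pyridine has so far given the lower numbers (compound 3), but only one such example exists.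

Compound 4 is therefore expected to stay close to compound 3, with a 1.2-fold higher number from compound 3 to compound 4 (0.09 log units; within the scatter) as the expected step, uncertain in sign. The estimate for compound 4 in this assay is 1100 nM, between 350 nM and 3500 nM.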

Compound 4, half-maximal inhibitory concentration: 300 nM
Compound 4: middle estimate off by 3.7-fold (0.56 log units), on the high side, outside the stated range (below it).
By their numbers in this assay, from the lowest: compound 4; then compounds 3 and 1 (each within the scatter of the next); then compound 2.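

In this assay, the position between two ring nitrogen atoms now separates two aromatic groups that are not pyridines: 5-chlorothiophen-2-yl in place of 4-methoxyphenyl gives a 3.0-fold lower number from compound 3 to compound 4 (0.48 log units; beyond the scatter), so the lower numbers do not rest on a single value shared by such groups. The same group also clears trifluoromethyl (a 3.3-fold lower number from compound 1 to compound 4 (0.52 log units; beyond the scatter)), which 4-methoxyphenyl in compound 3 did not do, and the range seen at this position widens to a 20-fold lower number from compound 2 to compound 4 (1.30 log units; beyond the scatter), leaving compound 4 with the lowest number, beyond the scatter of all three others. No measurement available here accounts for the size or direction of these steps.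

The change replaces the ring and its substituent together, so the compounds shown leave open whether the step follows the chlorine or the thiophene ring; unsubstituted thiophen-2-yl, 5-methylthiophen-2-yl and 4-chlorophenyl would divide the two. Also open, from the compounds shown here alone, is whether the step holds with another group in place of the ethoxycarbonyl group, such as a carboxylic acid or a primary amide, and whether an amine at this position fits the same order.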